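The source may report more compounds than this note shows. Statements on the series, on what has been measured and on what is new or still open speak of the compounds shown alone.

In a functional assay on MDA-MB-231 cells (Homo sapiens), read by microscopy and transwell migration, with a stated time of 24 h (a lower number here means a stronger inhibitor, a higher number a weaker inhibitor), compound 3 (`COc1ccc(C(=O)N(C)c2nc(-c3cc(OC)c(OC)c(OC)c3)cs2)cc1`) gives 312 nM. Compound 2 (`Cc1s/c(=N\C(=O)c2ccccc2)n(C)c1-c1ccccc1`) gives 197 nM, and the two values lie within the scatter of each other. Compound 1 (`COc1ccc(C(=O)Nc2nc(-c3cc(OC)c(OC)c(OC)c3)cs2)cc1`) has no number, only a limit of > 25000 nM.

The next structure is compound 4 (`COc1cccc(C(=O)N(C)c2nc(-c3cc(OC)c(OC)c(OC)c3)cs2)c1`), with 3-methoxyphenyl in place of 4-methoxyphenyl on a carbonyl carbon. Both compounds carry the same atoms, joined differently.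

For the measured compounds named here, only one measured step bears on this change, and it bears only indirectly. Methyl in place of hydrogen on an amide-type nitrogen gave an at least 80-fold lower number from compound 1 to compound 3 (1.90 log units; beyond the scatter), which is a large step resting on the limit of compound 1. That step lies at a different place from the present change, and compound 4 has the same methyl on the amide-type nitrogen as compound 3. Going by the values given here, no measured pair separates 3-methoxyphenyl from 4-methoxyphenyl, so no direction can be argued from the data. Among the compounds with values here, the working expectation in this assay is therefore no step beyond the scatter, with a wide margin on both sides given the size of the one measured step.

The expected step is a 1.1-fold higher number from compound 3 to compound 4 (0.05 log units; within the scatter). Compound 4 is estimated at 350 nM, with an expected range of 90 nM to 1500 nM.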

Compound 4, half-maximal inhibitory concentration: 646 nM
Compound 4: the middle estimate sits 1.8-fold (0.27 log units) below what was measured, within the range that was stated.
By their numbers in this assay, from the lowest: compounds 2 and 3 (each within the scatter of the next); then compound 4. At a limit, above all of these: compound 1.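

In this assay, 3-methoxyphenyl in place of 4-methoxyphenyl on the carbonyl carbon gives a 2.1-fold higher number from compound 3 to compound 4 (0.32 log units; beyond the scatter), so this position responds to where the methoxy group stands even though the two compounds carry the same atoms and the same counts of donors and acceptors. For the compounds shown here, until now, the only measured step lay on the amide-type nitrogen; this pair is the first to show a change on the aromatic ring of the carbonyl side that lies beyond the scatter, modest in size and favouring 4-methoxyphenyl, with the methyl on the amide-type nitrogen held constant. Nothing at hand gives a reason for this step.

As far as these compounds go, a single pair sets no trend, and it remains open whether the same order of 4-methoxyphenyl and 3-methoxyphenyl would hold with the amide hydrogen in place of the methyl. From the compounds shown here alone, it is equally open how this position would take a group of another kind, such as a dimethylamino group, a carboxylic acid or a longer chain such as butoxy in place of methoxy.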